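The source may hold more compounds than are shown below. What is called first, only, known or untested is meant among the compounds shown, and "the series" means these compounds.

Measured compounds:
Compound 1 `O=C(COc1cccc2ccccc12)N/N=C/c1ccc(Cl)cc1` — in a physicochemical assay for lipophilicity, measured as octanol-water partition (on this read-out higher numbers stand for higher lipophilicity and lower numbers for lower lipophilicity), compound 1 gives 4.54.
Compound 2 `O=C(COc1cccc2ccccc12)N/N=C/c1ccc(O)cc1` — in this assay compound 2 gives 3.73.
Compound 3 `O=C(COc1cccc2ccccc12)N/N=C/c1cccc(O)c1` — in this assay compound 3 gives 3.73.

Compound 3 sits level with compound 2 in this assay; the two share the lowest number of the three, and the step of no change at the digits printed from compound 2 to compound 3 (within the scatter) lies within the scatter. Going by the values given here, the only compound clearly apart is compound 1, reached by the step of a number 0.81 log units lower from compound 1 to compound 3 (beyond the scatter).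

Compound 4 `O=C(COc1cccc2ccccc12)N/N=C/c1ccccc1Br` has not been measured. It differs from compound 3 by 2-bromophenyl in place of 3-hydroxyphenyl on a carbon with a double bond to nitrogen.

Among the compounds with values here, two measured steps bear on this change. The step of a number 0.81 log units lower from compound 1 to compound 2 (beyond the scatter) and the step of a number 0.81 log units lower from compound 1 to compound 3 (beyond the scatter) each show that exchanging a halogen on the phenyl ring for a hydroxy lowers the number by a modest amount, and the step of no change at the digits printed from compound 2 to compound 3 (within the scatter) shows that where the hydroxy sits made no difference at the digits given. Going from compound 3 to compound 4 runs the halogen-to-hydroxy exchange in reverse, so a rise of roughly the same size is expected in this assay, with the step of a number 0.87 log units higher from compound 3 to compound 4 (beyond the scatter). Compound 4 is therefore expected to give about 4.6, within a range from 4.2 to 5, close to the number seen for compound 1.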

Compound 4, partition coefficient: 4.81
Compound 4: middle estimate off by 0.21 log units, on the low side, within the range that was stated.
By their numbers in this assay, from the lowest: compounds 2 and 3 (each within the scatter of the next); then compounds 1 and 4 (each within the scatter of the next).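

On a carbon with a double bond to nitrogen, 2-bromophenyl in place of a hydroxyphenyl gives a large rise in this assay, seen both as a number 1.08 log units higher from compound 3 to compound 4 (beyond the scatter) and as a number 1.08 log units higher from compound 2 to compound 4 (beyond the scatter). The earlier compounds had shown a rise of this kind only for 4-chlorophenyl, so the separation from the hydroxyphenyl compounds now holds for a second halogen and a different place on the phenyl ring. The two halogen compounds cannot be told apart, with a number 0.27 log units higher from compound 1 to compound 4 (within the scatter), and among these four compounds none goes against the split between the two hydroxyphenyl and the two halogen-bearing compounds. Nothing measured here offers an explanation for this result.

Since 2-bromophenyl and 4-chlorophenyl differ in both the halogen and where it sits, the compounds shown cannot separate these two influences, and any effect of either alone may be hidden within the scatter. As far as these compounds go, how a methoxy group, an amine or a carboxylic acid on the same phenyl ring would read in this assay also remains open.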